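The source may report more compounds than this note shows. Statements on the series, on what has been measured and on what is new or still open speak of the compounds shown alone.

Working notes on the amide series. Compound 1 `Cc1cccc(-c2ccnc(C(=O)Nc3ccc(Oc4ccnc5[nH]ccc45)cc3)c2)c1` in a functional assay on PC-3 cells (Homo sapiens) for cytotoxicity, read by MTT assay, with a stated time of 72 h (on this read-out higher numbers stand for weaker inhibition and lower numbers for stronger inhibition), gives 5470 nM. Compound 2 `Cc1cccc(-c2ccnc(C(=O)Nc3ccc(Oc4ccnc5[nH]ccc45)c(F)c3)c2)c1` in this assay gives 860 nM. Among the measured compounds shown here, the only measured step so far is a 6.4-fold lower number from compound 1 to compound 2 (0.80 log units; beyond the scatter). On the two numbers in hand compound 2 therefore stands with the lower number, and its nearest neighbour is compound 1.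

Compound 3 `CCc1ccc(-c2ccnc(C(=O)Nc3ccc(Oc4ccnc5[nH]ccc45)c(F)c3)c2)cc1` is the next member and has not yet been measured in this assay. It differs from compound 2 by 4-ethylphenyl in place of 3-methylphenyl on an aromatic carbon. For the measured compounds named here, no measured step bears on this change: the one step in hand, a 6.4-fold lower number from compound 1 to compound 2 (0.80 log units; beyond the scatter), concerns fluoro in place of hydrogen, and compound 2 and compound 3 both carry that fluoro unchanged. The data give no comparison of one substituted phenyl against another, so there is nothing to set a direction.

The expected step of a 1.0-fold higher number from compound 2 to compound 3 (0.02 log units; within the scatter) is accordingly set at no change beyond the scatter. Compound 3 is estimated in this assay at 900 nM, with a range from 300 nM to 3000 nM that is kept wide for want of any comparable step.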

Compound 3, half-maximal inhibitory concentration: 2960 nM
Compound 3: middle estimate off by 3.3-fold (0.52 log units), on the low side; the range from low to high includes it.
By their numbers in this assay, from the lowest: compound 2; then compounds 3 and 1 (each within the scatter of the next).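

In this assay, among the compounds shown here, this is the first reading of a change to the substituted phenyl on the carbon opposite the ring nitrogen, and the position is not indifferent to it: a 3.4-fold higher number from compound 2 to compound 3 (0.54 log units; beyond the scatter), with 4-ethylphenyl in place of 3-methylphenyl. The fluoro and the rest of the shared core stay the same across this step, so the change in number belongs to the phenyl substituent, but the step changes both the chain, from methyl to ethyl, and its place on the phenyl, from 3 to 4, and cannot separate the two. Nothing in hand accounts for the direction or the size of this step.

Open, as far as these compounds go, is whether the chain or its place on the phenyl carries the step, a question that 3-ethylphenyl or 4-methylphenyl would put directly, and whether the same step would hold without the fluoro. Also open, from the compounds shown here alone, is how this position responds to groups of another kind on the phenyl, such as an amine, a carboxylic acid or a longer chain like 4-butyl.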